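From Aminomethyl to Carbamoyl on the Shared Core

The source may hold more compounds than are shown below. What is called first, only, known or untested is meant among the compounds shown, and "the series" means these compounds.

Of the compounds shown here, three built on one core have been tested in a functional assay on A549 cells (Homo sapiens) for antiproliferative activity, read by MTT assay, with a stated time of 48 h; a lower number here means a stronger inhibitor, a higher number a weaker inhibitor. Compound 1, `CC(=O)OC/C1=C/C[C@](C)(CCC=C(C)C)/C=C/[C@@H](OC(=O)C=C(C)C)[C@](C)(OC(C)=O)/C=C/C1=O`, gives 15100 nM. Compound 2, `CO[C@]1(C)/C=C/C(=O)/C(CO)=C\C[C@](C)(CCC=C(C)C)/C=C/[C@H]1OC(=O)C=C(C)C`, gives 14400 nM. Compound 3, `CC(C)=CCC[C@]1(C)/C=C/[C@@H](OC(=O)C=C(C)C)[C@](C)(O)/C=C/C(=O)/C(CN(C)C)=C\C1`, gives 590 nM, the lowest of the three numbers; its distance to compound 2 and to compound 1 lies beyond the usual scatter, so compound 3 is the strongest inhibitor of the three.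

The next compound, compound 4, is `CC(C)=CCC[C@]1(C)/C=C/[C@@H](OC(=O)C=C(C)C)[C@](C)(O)/C=C/C(=O)/C(C(=O)N(C)C)=C\C1`. It differs from compound 3 in one place: dimethylcarbamoyl in place of (dimethylamino)methyl on a double-bonded ring carbon. Among the compounds with values here, no pair of measured compounds shows this change, so its size cannot be read from the numbers. Within the data shown here, compound 3 is the only compound carrying the (dimethylamino)methyl group, and it is also the only strong inhibitor here, a pattern that rests on a single compound. A weakening is therefore expected, an 8.5-fold higher number from compound 3 to compound 4 (0.93 log units; beyond the scatter), with the direction itself uncertain. Compound 4 is estimated at 5000 nM, within a range from 1000 nM to 20000 nM.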

Compound 4, half-maximal inhibitory concentration: 2700 nM
The estimate for compound 4 lay 1.9-fold (0.27 log units) above the measured number, within the range that was stated.
By their numbers in this assay, from the lowest: compound 3; then compound 4; then compounds 2 and 1 (each within the scatter of the next).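

In this assay, within the data shown here, this is the first direct reading at this double-bonded ring carbon, where a single change separates two compounds: dimethylcarbamoyl in place of (dimethylamino)methyl gives a 4.6-fold higher number from compound 3 to compound 4 (0.66 log units; beyond the scatter), a modest weakening. The step shows that the position responds to this change, yet the number does not climb as far as those of the other compounds on the shared core. The counts of hydrogen-bond donors and acceptors are the same for the two groups, and nothing available explains the step.

A pyrrolidin-1-ylmethyl group, a primary carboxamide or a carboxylic acid on this ring carbon could show how far the result depends on the nitrogen's substituents or on the carbonyl. On these data alone, it also remains open whether the step keeps its size when the hydroxy group on the ring is replaced by a methoxy group.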